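Benzyl in place of ethylcarbamoyl: solubility notes

The source may hold more compounds than are shown below. What is called first, only, known or untested is meant among the compounds shown, and "the series" means these compounds.

Values in a physicochemical assay for solubility (a lower number here means a less soluble compound, a higher number a more soluble compound), so far
- compound 1 `O=C1CC[C@@H](C(=O)N2CCC(NS(=O)(=O)c3cc(S(=O)(=O)c4ccccc4)ccc3C(F)(F)F)CC2)N1` gives 100000 nM
- compound 2 `CC(C)(C)C(=O)N1CCC[C@H]1C(=O)N1CCC(NS(=O)(=O)c2cc(S(=O)(=O)c3ccccc3)ccc2C(F)(F)F)CC1` gives 50000 nM
- compound 3 `CCNC(=O)N1CCC[C@H]1C(=O)N1CCC(NS(=O)(=O)c2cc(S(=O)(=O)c3ccccc3)ccc2C(F)(F)F)CC1` gives 100000 nM

Compound 3 stands level with compound 1 in this assay at the digits given, and the gap to the remaining compound reads a 2.0-fold higher number from compound 2 to compound 3 (0.30 log units; within the scatter) as the measured step.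

Compound 4 `O=C([C@@H]1CCCN1Cc1ccccc1)N1CCC(NS(=O)(=O)c2cc(S(=O)(=O)c3ccccc3)ccc2C(F)(F)F)CC1` is next. Its difference from compound 3 is benzyl in place of ethylcarbamoyl on an amine nitrogen in a ring and, in words, it is benzyl in place of ethylcarbamoyl on an amine nitrogen in a ring.

Going by the values given here, three measured steps bear on this part of the molecule: a 2.0-fold lower number from compound 1 to compound 2 (0.30 log units; within the scatter) as the first, no change at the digits printed from compound 1 to compound 3 (within the scatter) as the second, and the step above as the third. All are small, but none brings in benzyl, so they guide the new step only loosely. Compound 2, which also lacks ethylamino, gives 50000 nM and is the nearest guide to the direction. A modest move to a lower number is therefore expected, not clearly beyond the scatter, with real uncertainty on the low side.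

The expected step is a 2.0-fold lower number from compound 3 to compound 4 (0.30 log units; within the scatter) and remains an estimate until measured.

For compound 4 the estimated value is 50000 nM with an expected range of 12000 nM to 100000 nM in this assay as the read-out.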

Compound 4, solubility: 25000 nM
Beside the measured number, compound 4's estimate is 2.0-fold (0.30 log units) above it; the range from low to high includes it.
By their numbers in this assay, from the lowest: compounds 4, 2, 1 and 3 (each within the scatter of the next, the first and the last beyond it).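

The change of group on the amine nitrogen in a ring gives the series its first steps in this assay that lie beyond the scatter: benzyl in place of ethylcarbamoyl (a 4.0-fold lower number from compound 3 to compound 4 (0.60 log units; beyond the scatter)) and 1-benzylpyrrolidin-2-yl in place of 5-oxopyrrolidin-2-yl (a 4.0-fold lower number from compound 1 to compound 4 (0.60 log units; beyond the scatter)). Benzyl in place of (tert-butyl)carbonyl stays within the scatter (a 2.0-fold lower number from compound 2 to compound 4 (0.30 log units; within the scatter)), so on these numbers compound 4 cannot be told apart from compound 2, and the effect of this position depends on which group serves as the reference. No measurement on hand accounts for either larger step.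

Open, from the compounds shown here alone, is whether the steps follow from the aromatic ring of benzyl or from the loss of the carbonyl on this nitrogen, as compound 4 changes both at once. A cyclohexylmethyl group, a pyridylmethyl group, a plain ethyl group or the free ring amine at this position would help separate those two readings, and a benzoyl group would show what the aromatic ring does with the carbonyl retained.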